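The source may report more compounds than this note shows. Statements on the series, on what has been measured and on what is new or still open speak of the compounds shown alone.

Measured so far:
compound 1, `CCCN(CCC)c1nc(C(F)(F)F)ccc1CNC(=O)C(C)c1ccc(NS(C)(=O)=O)c(F)c1`: 14.7 nM
compound 2, `C[C@H](C(=O)NCc1ccc(C(F)(F)F)nc1N1CCC[C@H]1C(=O)N(C)C)c1ccc(NS(C)(=O)=O)c(F)c1`: "not active" (no number reported)
compound 3, `C[C@@H](C(=O)NCc1ccc(C(F)(F)F)nc1N1CCC(c2ccccc2)CC1)c1ccc(NS(C)(=O)=O)c(F)c1`: 2350 nM

Compound 1 carries a dipropylamino group next to the ring nitrogen of its core. In a functional assay on CHO-K1 cells for antagonist activity at transient receptor potential cation channel subfamily V member 1 (Homo sapiens), read by FLIPR (a lower number here means a stronger inhibitor, a higher number a weaker inhibitor), compound 1 gives 14.7 nM, the lowest of the two numbers on record. Compound 3, in which a cyclic amine with a phenyl substituent takes that place, gives 2350 nM in this assay, a much higher number; compound 2, with a different cyclic amine, is reported as "not active" (no number reported) in this assay without a number.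

Compound 4, `CC(C(=O)NCc1ccc(C(F)(F)F)nc1N1CCCCCCC1)c1ccc(NS(C)(=O)=O)c(F)c1`, has not yet been measured. It differs from compound 1 in one place: a group of 8 heavy atoms (7 carbon, 1 nitrogen; one eight-membered non-aromatic ring with 1 hetero atom) in place of a group of 7 heavy atoms (6 carbon, 1 nitrogen; no ring), on an aromatic carbon. The two cyclic amines already seen, in compound 2 and compound 3, gave much weaker results than compound 1; the eight-membered ring in compound 4 is, however, close in size to the dipropylamino group it replaces. A modest loss is therefore expected, with the step from compound 1 to compound 4 estimated at a 3.1-fold higher number from compound 1 to compound 4 (0.49 log units; beyond the scatter). Compound 4 is expected to give about 45 nM in this assay, in the range 10 nM to 250 nM.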

Compound 4, half-maximal inhibitory concentration: 27.8 nM
For compound 4 the middle estimate is 1.6-fold (0.21 log units) above the measured one, within the range that was stated.
By their numbers in this assay, from the lowest: compounds 1 and 4 (each within the scatter of the next); then compound 3.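

In this assay, putting the one eight-membered non-aromatic ring in place of dipropylamino, on the aromatic carbon next to the ring nitrogen, gives a 1.9-fold higher number from compound 1 to compound 4 (0.28 log units; within the scatter), so compound 1 and compound 4 cannot be told apart in this assay. Within the data shown here, an amine closed into a ring at this place is therefore not tied on its own to a large loss, something the earlier compounds with a cyclic amine here could not show. Nothing on record offers an explanation for this result.

The compounds shown leave open how a plain piperidine or pyrrolidine ring without substituents would behave at this place. They also leave open whether a diethylamino or dibutylamino group would stay as close to compound 1 as the eight-membered ring does.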